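A few compounds are considered here, and "the series" means these few. Any claim that something is new, unique, unknown or untested is made for them only; others in the source may bear on it.

Compound 1 `COc1ccc(-n2nc(C(=O)Nc3ccc(C)cc3)nc2-c2cc(OC)c(OC)c(OC)c2)cc1` and compound 2 `COc1ccc(-n2nc(C(=O)Nc3ccc(C(F)(F)F)cc3)nc2-c2cc(OC)c(OC)c(OC)c2)cc1` share one core and differ only at a single aromatic carbon, where compound 1 carries a methyl group and compound 2 a trifluoromethyl group. In a functional assay on the whole organism for inhibition, with Rattus norvegicus as the target, read by paw edema, with stated times of 30 min and 3 h, at a dose of 0.28 mmol/kg by the oral route (on this read-out higher numbers stand for more inhibition at the one dose given (going by the name of the read-out) and lower numbers for less inhibition), compound 1 gives 60%, and compound 2 gives 65%. The step of a number 5 percentage points higher from compound 1 to compound 2 (within the scatter) shows that these two numbers sit within the usual scatter of each other, so compound 2 stands level with compound 1 rather than apart from it.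

Compound 3 `COc1ccc(-n2nc(C(=O)Nc3ccc(C(=O)O)cc3)nc2-c2cc(OC)c(OC)c(OC)c2)cc1` takes the next step from compound 2: carboxy in place of trifluoromethyl on an aromatic carbon. Among the measured compounds shown here, the only measured step, from methyl to trifluoromethyl, stayed within the scatter and involved a group unlike carboxy, so it gives little guidance. The expectation is therefore a change of a number 10 percentage points lower from compound 2 to compound 3 (within the scatter), within the scatter. Compound 3 is estimated at 55%, with a range from 30% to 75%.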

Compound 3, a percentage reported as inhibition, in the whole organism at one dose (the size of the read-out at that dose, not a potency): 74%
The estimate for compound 3 lay 19 percentage points below the measured number; the measured number falls inside the stated range.
By their numbers in this assay, from the lowest: compounds 1, 2 and 3 (each within the scatter of the next, the first and the last beyond it).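

Replacing trifluoromethyl with carboxy at this aromatic carbon, para to a large group, gives a number 9 percentage points higher from compound 2 to compound 3 (within the scatter) in this assay. The position therefore accepts a carboxy group, with its hydrogen-bond donor and acceptor, in place of a group that has neither, with no loss in this read-out. Against methyl, the same group gives a number 14 percentage points higher from compound 1 to compound 3 (beyond the scatter), so this is the first step in the series that clears the usual spread of the measurements, though the available data offer no explanation for it.

Going by these compounds, it remains open whether this result is particular to the carboxy group or would also hold for other groups with a hydrogen-bond donor. An amine, a hydroxyl group or a methyl ester at the same position would help to separate these possibilities.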